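Swapping cyclopentylmethyl for 3-fluorophenyl: an expected loss

The compounds below may be only part of what the source reports. "The series", "measured", "known", "first", "only" and "open" are said of these compounds alone.

Among the measured compounds shown here, in a functional assay on Jurkat cells (Homo sapiens) (on this read-out higher numbers stand for weaker inhibition and lower numbers for stronger inhibition), compound 1 `C[C@H](NC(=O)C(=O)NCCC1CCCC1)C(=O)N[C@@H](CC(=O)O)C(=O)COc1c(F)c(F)cc(F)c1F` gives 11 nM, the lowest of the three numbers measured so far. Compound 2 `C[C@H](NC(=O)C(=O)NCC1(c2ccccc2)CC1)C(=O)N[C@@H](CC(=O)O)C(=O)COc1c(F)c(F)cc(F)c1F` gives 27 nM, and compound 3 `Cc1cccc(CNC(=O)C(=O)N[C@@H](C)C(=O)N[C@@H](CC(=O)O)C(=O)COc2c(F)c(F)cc(F)c2F)c1` gives 127 nM. Compound 4 `C[C@H](NC(=O)C(=O)NCc1cccc(F)c1)C(=O)N[C@@H](CC(=O)O)C(=O)COc1c(F)c(F)cc(F)c1F` has not yet been measured. It differs from compound 1 in one place: 3-fluorophenyl in place of cyclopentylmethyl on a saturated chain carbon bound to an amide-type nitrogen. Here, 3-fluorophenyl stands in place of cyclopentylmethyl on a saturated chain carbon bound to an amide-type nitrogen.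

Two measured steps change that same place. Putting in 1-phenylcyclopropyl gave a 2.5-fold higher number from compound 1 to compound 2 (0.39 log units; beyond the scatter), a modest step. Putting in 3-methylphenyl, the group most like 3-fluorophenyl, gave a 12-fold higher number from compound 1 to compound 3 (1.06 log units; beyond the scatter), a large step. For the measured compounds named here, no measurement yet compares a fluorine with a methyl on this ring, so the second step is only a guide. A large move towards a higher number, meaning weaker inhibition, is therefore expected in this assay. The expected step is a 9.1-fold higher number from compound 1 to compound 4 (0.96 log units; beyond the scatter). Compound 4 is estimated at 100 nM, with an expected range of 35 nM to 280 nM.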

Compound 4, half-maximal inhibitory concentration: 106 nM
Compound 4: the middle estimate sits 1.1-fold (0.03 log units) below what was measured; measured number inside the range.
By their numbers in this assay, from the lowest: compound 1; then compound 2; then compounds 4 and 3 (each within the scatter of the next).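

The new information is the direct comparison of fluoro with methyl on the aromatic carbon: the two cannot be told apart in this assay (a 1.2-fold lower number from compound 3 to compound 4 (0.08 log units; within the scatter)). The loss on leaving the 2-cyclopentylethyl group therefore also appears with 3-fluorobenzyl (a 9.6-fold higher number from compound 1 to compound 4 (0.98 log units; beyond the scatter)), and 3-fluorophenyl also gives a higher number than 1-phenylcyclopropyl (a 3.9-fold higher number from compound 2 to compound 4 (0.59 log units; beyond the scatter)). No measured evidence accounts for these differences.

From the compounds shown here alone, the step from 2-cyclopentylethyl to 3-fluorobenzyl changes both the ring and the chain length, so the effect of each alone remains unknown; a 2-phenylethyl group would keep the chain of compound 1 while carrying an aromatic ring. Also open, going by these compounds, is how this position responds to a more different group on the aromatic ring, such as an amine or a carboxylic acid.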